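A few compounds are considered here, and "the series" means these few. Any claim that something is new, unique, unknown or untested is made for them only; others in the source may bear on it.

In an ADME assay on L6 cells (Rattus norvegicus) for cytotoxicity (a higher number here means a weaker inhibitor, a lower number a stronger inhibitor), compound 3 (`O=C(Nc1c(O)cccc1-c1nc2c(C(=O)O)cccc2o1)c1ccc(F)c(F)c1F`) gives 210000 nM. Compound 1 (`O=C(Nc1c(O)cccc1-c1nc2c(C(=O)O)cccc2o1)c1ncccc1F`) gives 204000 nM, and the two form a level pair, with a 1.0-fold higher number from compound 1 to compound 3 (0.01 log units; within the scatter). Compound 2 (`O=C(Nc1c(O)cccc1-c1nc2c(C(=O)O)cccc2o1)c1ccccc1O`) gives 85100 nM and stands apart from both, with a 2.4-fold lower number from compound 1 to compound 2 (0.38 log units; beyond the scatter) and a 2.5-fold higher number from compound 2 to compound 3 (0.39 log units; beyond the scatter).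

The next change leads to compound 4 (`O=C(Nc1c(O)cccc1-c1nc2c(C(=O)O)cccc2o1)c1ccccc1`), with phenyl in place of 2,3,4-trifluorophenyl on a carbonyl carbon. Going by the values given here, no measured pair isolates this exact change, so the evidence comes only from the other swaps at the same place. Among the compounds with values here, those swaps span a narrow range: the one between compound 1 and compound 3 stayed within the scatter, and the two involving compound 2 were modest. On these three compounds, no step beyond the scatter is expected in this assay, and the direction is not firmly set. A slight lean toward the value of compound 2 is allowed, as the unsubstituted phenyl has no clear match among the measured groups. The estimate for the change is a 1.4-fold lower number from compound 3 to compound 4 (0.15 log units; within the scatter), which is expected to lie within the scatter. Compound 4 is expected at about 150000 nM, with an estimated range of 75000 nM to 280000 nM.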

Compound 4, half-maximal inhibitory concentration: > 240000 nM
Compound 4 was reported as a limit; the forecaster's own chance of this, stated with the estimate: 10%; middle value at least 1.6-fold (0.20 log units) away from the limit.
By their numbers in this assay, from the lowest: compound 2; then compounds 1 and 3 (each within the scatter of the next). At a limit, above all of these: compound 4.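

In this assay compound 4 is reported only as a limit and not as a number: the limit of > 240000 nM in this assay, at which 1 of the 4 values shown sits. Hydrogen in place of hydroxy on an aromatic carbon gives an at least 2.8-fold higher number from compound 2 to compound 4 (0.45 log units; beyond the scatter), and this floor is beyond the scatter, so the lower number of compound 2 now traces to that single hydroxy group, a link that the earlier swaps, each of which changed the whole group on the carbonyl carbon, could not isolate. The other two steps are an at least 1.1-fold higher number from compound 3 to compound 4 (0.05 log units; that floor lies within the scatter) and an at least 1.1-fold higher number from compound 1 to compound 4 (0.07 log units; that floor lies within the scatter), and both floors lie within the scatter, so the plain phenyl group joins the 2,3,4-trifluorophenyl and 3-fluoropyridin-2-yl groups on the weak side of the series, and neither the fluorines nor the ring nitrogen of the pyridine is needed to keep the number high.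

From the compounds shown here alone, how far compound 4 lies beyond its limit stays open, and with it the true size of all three steps. Also open, going by these compounds, is whether an amine or a methoxy group in place of the hydroxy would bring the number down as the hydroxy does, or whether that drop is particular to the hydroxy group.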